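The compounds below may be only part of what the source reports. "The series", "measured", "known", "first", "only" and "open" are said of these compounds alone.

Measured compounds in an assay on HEK293 cells for inhibition of Steryl-sulfatase (Homo sapiens), tested at 0.1 uM; on this read-out higher numbers stand for a stronger effect at the one concentration tested and lower numbers for a weaker effect:
- compound 1 `CCN(Cc1ccccc1)c1cccc(C(=O)N2CCc3ccc(OS(N)(=O)=O)cc3C2)c1`: 17.3%
- compound 2 `CN(C)CCN(CCN(C)C)c1cccc(C(=O)N2CCc3ccc(OS(N)(=O)=O)cc3C2)c1`: 0%
- compound 3 `CCCN(Cc1ccccc1)c1cccc(C(=O)N2CCc3ccc(OS(N)(=O)=O)cc3C2)c1`: 23.1%

Compound 3 gives the highest of the three numbers in this assay; its nearest neighbour is compound 1, with a number 5.8 percentage points higher from compound 1 to compound 3 (within the scatter), and the furthest is compound 2, with a number 23.1 percentage points higher from compound 2 to compound 3 (beyond the scatter).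

Compound 4 `CCN(Cc1ccccn1)c1cccc(C(=O)N2CCc3ccc(OS(N)(=O)=O)cc3C2)c1` differs from compound 3 in one place: ethyl((pyridin-2-yl)methyl)amino in place of benzyl(propyl)amino on an aromatic carbon. For the measured compounds named here, two measured steps bear on this. The step of a number 5.8 percentage points higher from compound 1 to compound 3 (within the scatter) shows that trading propyl for ethyl on the amine nitrogen hardly moves the read-out. The step of a number 17.3 percentage points lower from compound 1 to compound 2 (beyond the scatter) shows that removing the benzyl group altogether and installing two amine-bearing chains costs a modest amount. The pyridin-2-ylmethyl group keeps the aromatic ring and only adds one ring nitrogen, so the change is expected to fall between these cases, with a small drop or none beyond the scatter. The step of a number 8.1 percentage points lower from compound 3 to compound 4 (within the scatter) is the expected size. Compound 4 is therefore estimated at 15%, within a range of 3% to 28%.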

Compound 4, a percentage reported as inhibition, at one concentration (the size of the read-out at that concentration, not a potency): 6.5%
Estimate against measurement, compound 4: 8.5 percentage points above; low and high end bracket the measured number.
By their numbers in this assay, from the lowest: compounds 2 and 4 (each within the scatter of the next); then compounds 1 and 3 (each within the scatter of the next).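

In this assay, the exchange of phenyl for pyridin-2-yl on a saturated chain carbon bound to a nitrogen on an aromatic ring gives a number 10.8 percentage points lower from compound 1 to compound 4 (beyond the scatter), so a single ring nitrogen in this group changes the read-out, whereas the ethyl and propyl chains of the earlier pair did not separate. The full exchange of benzyl(propyl)amino for ethyl((pyridin-2-yl)methyl)amino goes the same way, with a number 16.6 percentage points lower from compound 3 to compound 4 (beyond the scatter). Keeping an aromatic ring is thus not enough to hold the read-out, as the comparison with the ringless bis(2-(dimethylamino)ethyl)amino group shows a number 6.5 percentage points higher from compound 2 to compound 4 (within the scatter).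

The data shown offer no measured explanation for this loss. As far as these compounds go, how pyridin-3-yl, pyridin-4-yl or a phenyl ring carrying a methoxy group would read at this position remains open.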